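Bromo at a new place on a carbamate series

The compounds below may be only part of what the source reports. "The series", "measured", "known", "first", "only" and "open" are said of these compounds alone.

Compound 1, `C=C1C(=O)OC[C@H]1CCOC(=O)Nc1cccc(Br)c1`, gives 590 nM.
Compound 2, `C=C1C(=O)OC[C@@H]1CCOC(=O)Nc1ccccc1`, gives 780 nM.
Compound 3, `C=C1C(=O)OC[C@H]1CCOC(=O)Nc1ccccc1`, gives 390 nM.

These three numbers come from a functional assay on RAW264.7 cells (Mus musculus) for inhibition, with a stated time of 30 min; on this read-out lower numbers stand for stronger inhibition and higher numbers for weaker inhibition. Compound 2 and compound 3 share every atom and bond; their cores differ only as follows: the two compounds have the same atoms and bonds and differ only in configuration as drawn: 1 of 1 stereo elements differ; a stereocentre at a saturated ring carbon is drawn S in compound 3 and R in compound 2. The step between them is a 2.0-fold lower number from compound 2 to compound 3 (0.30 log units; within the scatter), so the two numbers cannot be told apart here, and the fact that compounds 2 and 3 differ only in the configuration as drawn is all that separates the two structures.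

From compound 3 to compound 1 the change is bromo in place of hydrogen on an aromatic carbon, and it made a step of a 1.5-fold higher number from compound 3 to compound 1 (0.18 log units; within the scatter). The unmeasured compound 4, `C=C1C(=O)OC[C@@H]1CCOC(=O)Nc1ccc(Br)cc1`, arises from compound 2 by the same kind of change, (bromo in place of hydrogen on an aromatic carbon). The two places are not the same: in compound 1 the bromo sits meta to a large group, in compound 4 it sits para to a large group, so the change is of the same kind but not the same.

With one earlier step of this kind, which stayed within the scatter, compound 4 is expected to land near compound 2, with an estimated step of a 1.3-fold higher number from compound 2 to compound 4 (0.11 log units; within the scatter), resting on the step of a 1.5-fold higher number from compound 3 to compound 1 (0.18 log units; within the scatter) seen in the meta case. Compound 4 is therefore expected to give about 1000 nM in this assay, with a likely range from 400 nM to 2500 nM.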

Compound 4, half-maximal inhibitory concentration: 720 nM
Compound 4: middle estimate off by 1.4-fold (0.14 log units), on the high side; measured number inside the range.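

In this assay, within the data shown here, putting bromo in place of hydrogen para to a large group gives a 1.1-fold lower number from compound 2 to compound 4 (0.03 log units; within the scatter), so on this core the change leaves no step that can be told from the usual scatter of repeated measurements. Set beside the earlier case, the change stays small on both cores, and the two steps cannot be told apart: the same change on two cores in this assay, a 1.5-fold higher number (0.18 log units; within the scatter) from compound 3 to compound 1 and a 1.1-fold lower number (0.03 log units; within the scatter) from compound 2 to compound 4, 1.6-fold (0.21 log units) apart, within the scatter of two such steps. Among these compounds, this shows only that a small step was seen twice; it does not show that bromo would behave the same way at any place on the ring or on any other core, since the two cases differ in both the place of the bromo and the configuration as drawn, and a change with no clear step on either core is a weak test of carrying an effect across.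

The compounds shown leave open what bromo para to a large group would give on the configuration of compound 3, and what bromo at the place it holds in compound 1 would give on the configuration of compound 2, the two cases that would separate place from configuration. They also leave open whether a different group on the same ring, such as an amine or a carboxylic acid, would give a step beyond the scatter and, if so, whether that step would carry from one configuration to the other.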